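Changing One Ring Group, Watching What Cells Tolerate

A few compounds are considered here, and "the series" means these few. Any claim that something is new, unique, unknown or untested is made for them only; others in the source may bear on it.

Compound 1 `C=C1CC[C@@H]2[C@](C)(CO)[C@H](O)CC[C@@]2(C)[C@@H]1C/C=C1/C(=O)OC[C@@H]1Oc1cccc2ccc(C)nc12` and compound 2 `C=C1CC[C@@H]2[C@](C)(COC(C)=O)[C@H](O)CC[C@@]2(C)[C@@H]1C/C=C1/C(=O)OC[C@H]1Oc1cccc2ccc(C)nc12` share a core, and the difference between the two cores is not broken down here. In an ADME assay on SNB-19 cells (Homo sapiens) for cytotoxicity, read by MTT assay, with a stated time of 24 h (a lower number here means that less compound is tolerated, a higher number that more compound is tolerated), compound 1 gives > 100000 nM, which is a limit of the assay rather than a number. Compound 2 gives > 100000 nM, also a limit. Compound 3 `C=C1CC[C@@H]2[C@](C)(CO)[C@H](O)CC[C@@]2(C)[C@@H]1C/C=C1/C(=O)OC[C@@H]1Oc1c(Cl)cc(Cl)c2cccnc12` differs from compound 1 by 5,7-dichloroquinolin-8-yl in place of 2-methylquinolin-8-yl on an oxygen on a saturated carbon, and compound 3 gives > 100000 nM, again a limit. The step that the two limits leave unreadable from compound 1 to compound 3 cannot be sized because of the limit of > 100000 nM in this assay, at which 3 of the 3 values shown sit. Compound 4 `C=C1CC[C@@H]2[C@](C)(COC(C)=O)[C@H](O)CC[C@@]2(C)[C@@H]1C/C=C1/C(=O)OC[C@H]1Oc1c(Cl)cc(Cl)c2cccnc12` carries the same kind of change on the core of compound 2: 5,7-dichloroquinolin-8-yl in place of 2-methylquinolin-8-yl on an oxygen on a saturated carbon. The step of a number no higher from compound 2 to compound 4 (the limit leaves the size open) is expected to be flat, resting on the unreadable step that the two limits leave unreadable from compound 1 to compound 3 from compound 1 to compound 3 and on the limit of compound 2. Compound 4 is therefore estimated at 100000 nM.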

Compound 4, half-maximal cytotoxic concentration: 88700 nM
Estimate against measurement, compound 4: 1.1-fold (0.05 log units) above, and the stated range covers the measured number.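

In this assay, putting 5,7-dichloroquinolin-8-yl in place of 2-methylquinolin-8-yl gives an at least 1.1-fold lower number from compound 2 to compound 4 (0.05 log units; that floor lies within the scatter). The same change on the core of compound 1 cannot be read, and so the two cores cannot be compared for this change, because both ends of that step are limits rather than numbers: the limit of > 100000 nM in this assay, at which 3 of the 4 values shown sit. Compound 4 therefore gives one measured number, but it does not show that the change lowers the tolerated concentration on either core, or that it acts alike on both.

On these data alone, what remains open is how tolerance responds to other groups on this oxygen. An amine or a carboxylic acid in place of the 2-methylquinolin-8-yl could give a number that shows this.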